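Ester to methylamide at the carbonyl of the shared core

This account rests on a few compounds, and the source may have more. Where it says the series, first, only, none or still open, it means among the compounds named here.

Two compounds of the series have numbers in a physicochemical assay for solubility, read by HPLC, in phosphate buffer, with a stated time of 4 h, at pH 7.4; on this read-out lower numbers stand for lower solubility and higher numbers for higher solubility. Compound 1 `Cc1cc(/C=C/C#N)cc(C)c1Oc1cc(Nc2ccc(C#N)cc2)c(N)cc1C(=O)NCCCO` gives 1.01 ug/mL in this assay. Compound 2 `COC(=O)c1cc(N)c(Nc2ccc(C#N)cc2)cc1Oc1c(C)cc(/C=C/C#N)cc1C` gives 1.21 ug/mL in this assay. Within the data shown here, the one measured step, a 1.2-fold higher number from compound 1 to compound 2 (0.08 log units; within the scatter), leaves compound 2 standing beside compound 1 rather than apart from it.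

Compound 3 `CNC(=O)c1cc(N)c(Nc2ccc(C#N)cc2)cc1Oc1c(C)cc(/C=C/C#N)cc1C` has not yet been measured in this assay. It differs from compound 2 by methylamino in place of methoxy on a carbonyl carbon. Among the measured compounds shown here, the only measured step that bears on this place is the exchange at the same carbonyl carbon, a 1.2-fold higher number from compound 1 to compound 2 (0.08 log units; within the scatter), which did not move the number beyond the scatter. On that basis the step from compound 2 to compound 3 is expected to be small, estimated as a 1.1-fold lower number from compound 2 to compound 3 (0.04 log units; within the scatter), with no direction beyond the scatter. Compound 3 is therefore estimated at 1.1 ug/mL in this assay, with a range from 0.5 ug/mL to 2.5 ug/mL.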

Compound 3, solubility: 8.28 ug/mL
Beside the measured number, compound 3's estimate is 7.5-fold (0.88 log units) below it; measured number outside the range, above it.
By their numbers in this assay, from the lowest: compounds 1 and 2 (each within the scatter of the next); then compound 3.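

In this assay the exchange at this carbonyl carbon is no longer silent: methylamino in place of methoxy gives a 6.8-fold higher number from compound 2 to compound 3 (0.84 log units; beyond the scatter) and sets compound 3 apart from compound 2. On the amide side, hydrogen in place of 2-hydroxyethyl on a saturated chain carbon bound to an amide-type nitrogen gives an 8.2-fold higher number from compound 1 to compound 3 (0.91 log units; beyond the scatter), so the change also registers further out along the chain. The higher number therefore does not follow from an amide at this carbon as such, since compound 1 is also an amide and goes against that reading; among these compounds it appears only with the methylcarbamoyl group of compound 3.

As far as these compounds go, whether a primary carboxamide, a dimethylamide or an ethylamide at the same carbonyl carbon would stay with compound 3 or sit with compound 1 and compound 2 remains open. Nothing available here bears on the origin of these steps.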